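Fluoro in place of dimethylamino: an expected step

The compounds below may be only part of what the source reports. "The series", "measured", "known", "first", "only" and "open" are said of these compounds alone.

- Compound 1 `O=C(O)CCC/C=C\C[C@H]1[C@@H]2CCC(C2)[C@@H]1NS(=O)(=O)c1ccc([N+](=O)[O-])cc1`: 1400 nM
- Compound 2 `Cc1cccc(S(=O)(=O)N[C@H]2C3CC[C@H](C3)[C@@H]2C/C=C\CCCC(=O)O)c1`: 1700 nM
- Compound 3 `CN(C)c1ccc(S(=O)(=O)N[C@H]2C3CC[C@H](C3)[C@@H]2C/C=C\CCCC(=O)O)cc1`: 7100 nM

All three values come from a functional assay (plasma) for inhibition, with Oryctolagus cuniculus as the target; on this read-out lower numbers stand for stronger inhibition and higher numbers for weaker inhibition. Compound 3 has the highest number of the three, and its steps to the other two lie beyond the scatter, so it is the weakest inhibitor of this small set.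

Compound 4 `O=C(O)CCC/C=C\C[C@H]1[C@@H]2CCC(C2)[C@@H]1NS(=O)(=O)c1ccc(F)cc1` has not yet been measured. It carries fluoro in place of dimethylamino on an aromatic carbon, para to a large group: fluoro in place of dimethylamino on an aromatic carbon.

Two measured steps end on the same dimethylamino group: a 5.1-fold higher number from compound 1 to compound 3 (0.71 log units; beyond the scatter), and a 4.2-fold higher number from compound 2 to compound 3 (0.62 log units; beyond the scatter). Both are modest and point the same way. The third step, a 1.2-fold higher number from compound 1 to compound 2 (0.08 log units; within the scatter), lies within the scatter, so compound 1 and compound 2 cannot be told apart despite their different groups. Within the data shown here, no compound with fluoro has been measured, so the expectation rests on three compounds only. If compound 4 behaves like compound 1 and compound 2, a modest step to a lower number is expected, reversing the size of those two steps.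

The expected step is a 3.6-fold lower number from compound 3 to compound 4 (0.55 log units; beyond the scatter). For compound 4 the estimated value is 2000 nM, with an expected range from 800 nM to 5000 nM.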

Compound 4, half-maximal inhibitory concentration: 600 nM
The estimate for compound 4 lay 3.3-fold (0.52 log units) above the measured number; the measured number lies below the stated range.
By their numbers in this assay, from the lowest: compound 4; then compounds 1 and 2 (each within the scatter of the next); then compound 3.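

In this assay, fluoro in place of dimethylamino on this aromatic carbon gives a 12-fold lower number from compound 3 to compound 4 (1.07 log units; beyond the scatter) and is the largest step in the set, so this group can shift the number further than the first three compounds revealed. Compound 1 and compound 2 could not be told apart, yet compound 4 falls clearly below both, with a 2.8-fold lower number from compound 2 to compound 4 (0.45 log units; beyond the scatter) and a 2.3-fold lower number from compound 1 to compound 4 (0.37 log units; beyond the scatter); both steps are modest but beyond the scatter, which makes compound 4 the strongest inhibitor of the four and shows that the earlier pair did not mark the low end of this small series. Nothing measured here accounts for the advantage of fluoro over the other groups.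

Still open, going by these compounds, is how chloro, methoxy or a plain hydrogen at this same place would compare with fluoro, and therefore whether fluoro stands alone or is one of several groups that give low numbers. Also open, on these data alone, is whether the fluoro gain would survive a change elsewhere, such as a shorter chain carrying the carboxylic acid.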